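Cutting back the long chain of compound 3

This account rests on a few compounds, and the source may have more. Where it says the series, first, only, none or still open, it means among the compounds named here.

In a functional assay on MDA-MB-231 cells (Homo sapiens) for inhibition, read by MTT assay, with stated times of 18 h and 4 h (a higher number here means a weaker inhibitor, a lower number a stronger inhibitor), compound 3 `CCCCCCCCCCCCCCCCOP(=O)(O)OCCSC(=S)N1CCN(C)CC1` gives > 100000 nM as its reading, which is a limit of the assay and not a number.

Compound 4 `CCCCCCCCOP(=O)(O)OCCSC(=S)N1CCN(C)CC1` differs from it by one change, hydrogen in place of octyl on a saturated chain carbon, eight bonds along the chain from an oxygen on an unsaturated carbon and so carries a shorter chain. Two relatives have the same chain as compound 4 and do give numbers: compound 1 `CCCCCCCCOP(=O)(O)OCCSC(=S)N1CCCC1` reads 69000 nM and compound 2 `CCCCCCCCOP(=O)(O)OCCSC(=S)N1CCCCC1` reads 11900 nM in the same test. Within the data shown here, the one measured step, a 5.8-fold lower number from compound 1 to compound 2 (0.76 log units; beyond the scatter) puts piperidin-1-yl in place of pyrrolidin-1-yl on a thiocarbonyl carbon. It does not touch the chain, so it shows only how far a single change can move compounds with this chain. Among the measured compounds shown here, no measured step shortens a chain. Compound 4 is therefore expected to fall near compounds 1 and 2 rather than stay at the limit. The expected change is an at least 3.3-fold lower number from compound 3 to compound 4 (0.52 log units; beyond the scatter) in this assay toward a stronger inhibitor, though with much uncertainty. For compound 4 the estimated value is 30000 nM with an expected range from 8000 nM to 100000 nM in this measurement.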

Compound 4, half-maximal inhibitory concentration: 58500 nM
For compound 4 the middle estimate is 2.0-fold (0.29 log units) below the measured one; the range from low to high includes it.
By their numbers in this assay, from the lowest: compound 2; then compounds 4 and 1 (each within the scatter of the next). At a limit, above all of these: compound 3.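

Shortening the chain gives compound 4 a true reading where compound 3 has only a limit of the assay, and the step is an at least 1.7-fold lower number from compound 3 to compound 4 (0.23 log units; that floor lies within the scatter) and cannot be sized more exactly. With the chain of compound 4, the group on the thiocarbonyl carbon can now be compared across three compounds: there is a 1.2-fold lower number from compound 1 to compound 4 (0.07 log units; within the scatter) but a 4.9-fold higher number from compound 2 to compound 4 (0.69 log units; beyond the scatter) and so piperidin-1-yl alone sets its compound apart. Going by these compounds, the true size of the chain step stays unknown because one end of it is a limit: the limit of > 100000 nM in this assay, at which 1 of the 4 values shown sits.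

On these data alone, how the numbers change for chains between octyl and the longer chain of compound 3, such as decyl or dodecyl, remains open. So does whether a morpholin-4-yl group on the thiocarbonyl carbon would read nearer compound 2 or nearer compounds 1 and 4.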